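The source may report more compounds than this note shows. Statements on the series, on what has been measured and on what is new or still open speak of the compounds shown alone.

Measured in an in vitro ADME assay on microsomes from liver (Simiiformes); on this read-out lower numbers stand for a shorter-lived compound and higher numbers for a longer-lived compound:
- Compound 1 `Cc1cc(CCCOc2c(C)cc(-c3noc(CF)n3)cc2C)on1`: 0.233 h
- Compound 2 `CCOc1nc(-c2cc(C)c(OCCCc3cc(C)no3)c(C)c2)no1`: > 2.5 h

Compound 2 stands at the limit of this assay, with > 2.5 h. Going by these compounds, this is a limit and not a number, so its exact place is unknown.

Compound 3 `Cc1cc(CCCOc2c(C)cc(-c3noc(C(C)(F)F)n3)cc2C)on1` changes the ethoxy group of compound 2: 1,1-difluoroethyl in place of ethoxy on an aromatic carbon. In words, 1,1-difluoroethyl comes in place of ethoxy on an aromatic carbon.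

Among the compounds with values here, only one measured step bears on this change. It also involves ethoxy and is large and beyond the scatter: an at least 10-fold higher number from compound 1 to compound 2 (1.03 log units; beyond the scatter). Within the data shown here, no measured compound carries 1,1-difluoroethyl, but compound 3 resembles compound 1 in having a fluorinated group instead of ethoxy. Part of that large step may therefore be lost, and a lower number is expected.

The expected change is an at least 2.5-fold lower number from compound 2 to compound 3 (0.39 log units; beyond the scatter). For compound 3 the estimate is 1 h, with an expected range of 0.3 h to 3.5 h.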

Compound 3, half-life: 1.1 h
For compound 3 the middle estimate is 1.1-fold (0.04 log units) below the measured one; the measured number falls inside the stated range.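

In this assay, a third group at this position on the five-membered ring gives an at least 2.2-fold lower number from compound 2 to compound 3 (0.35 log units; beyond the scatter), so replacing ethoxy with a fluorinated group need not bring the half-life all the way back to that of the fluoromethyl compound. How large this drop is remains uncertain, and compound 2 gives a limit, not a number: the limit of > 2.5 h in this assay, at which 1 of the 3 values shown sits. The two fluorinated groups also differ from each other, with a 4.7-fold higher number from compound 1 to compound 3 (0.67 log units; beyond the scatter), so the presence of fluorine alone does not settle the half-life.

What remains open is why these groups differ, since the compounds shown do not separate the oxygen of ethoxy from the fluorines of 1,1-difluoroethyl. A plain ethyl group or a trifluoromethyl group at this position would help show how much each of these features counts.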